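Swapping a Ring Hydrogen for Benzyloxy: Expected Response

The source may report more compounds than this note shows. Statements on the series, on what has been measured and on what is new or still open speak of the compounds shown alone.

Measured compounds:
Compound 1 `Nc1nc(O)c2c(n1)n(C1OC(CO)[C@@H](O)[C@H]1O)c(=O)n2Cc1ccc(Cl)cc1` — 15%
Compound 2 `Nc1nc(O)c2c(n1)n(C1OC(CO)[C@@H](O)[C@H]1O)c(=O)n2Cc1ccc([N+](=O)[O-])cc1` — 147%
Compound 3 `Nc1nc(O)c2c(n1)n(C1OC(CO)[C@@H](O)[C@H]1O)c(=O)n2Cc1ccccc1` — 110%

These three compounds share one core and differ only in the group that sits on the aromatic ring at the end of the benzyl arm. In a functional assay on the whole organism (B cells) with Mus musculus as the target (on this read-out lower numbers stand for smaller maximal responses and higher numbers for larger maximal responses), compound 3 stands second highest of the three: compound 2 lies above it, as a number 37 percentage points lower from compound 2 to compound 3 (beyond the scatter) shows, and compound 1 lies far below, as a number 95 percentage points higher from compound 1 to compound 3 (beyond the scatter) shows. Both steps are beyond the scatter, so the group at this position clearly matters, and it can push the response either way.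

Compound 4 `Nc1nc(O)c2c(n1)n(C1OC(CO)[C@@H](O)[C@H]1O)c(=O)n2Cc1ccc(OCc2ccccc2)cc1` carries a new group there: benzyloxy in place of hydrogen on an aromatic carbon. Among the compounds with values here, no measured step involves benzyloxy, so the two steps above are the only guide, and they point in opposite directions by large amounts. The expectation for compound 4 is therefore a response near that of compound 3, with a wide range, giving an estimated 95% between 25% and 150%. This expected step, a number 15 percentage points lower from compound 3 to compound 4 (beyond the scatter), is small compared with the measured swings, but the uncertainty around it is large.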

Compound 4, largest response reached (reported as maximal response), in percent of the reference or control that the assay uses: 5%
Compound 4: middle estimate off by 90 percentage points, on the high side; the whole stated range lies above it.
By their numbers in this assay, from the lowest: compounds 4 and 1 (each within the scatter of the next); then compound 3; then compound 2.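

In this assay, benzyloxy on this aromatic carbon brings a steep fall in response from the unsubstituted ring (a number 105 percentage points lower from compound 3 to compound 4 (beyond the scatter)) and an even steeper one from the nitro compound (a number 142 percentage points lower from compound 2 to compound 4 (beyond the scatter)). Until now, only chloro had given a low response, and benzyloxy, a far larger group, lands at much the same level (a number 10 percentage points lower from compound 1 to compound 4 (within the scatter)). Group size alone therefore does not sort these compounds, since small chloro and large benzyloxy both give low responses, while nitro, which is larger than chloro, gives the highest. Nothing measured here explains why these groups differ so sharply.

Still open, on these data alone, is whether the outer ring of benzyloxy is needed for the low response, or whether a methoxy group would give the same result. It is also unclear where an amine or a carboxylic acid on this carbon would fall in the wide span between chloro and nitro.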